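Phenyl for Formyl on the Ring Nitrogen: An Expectation

The source may report more compounds than this note shows. Statements on the series, on what has been measured and on what is new or still open speak of the compounds shown alone.

Compound 1 `Cc1ccc(C2=NN(c3ccc([N+](=O)[O-])cc3)C(c3cn(-c4ccccc4)nc3-c3ccc(Cl)c(Cl)c3)C2)cc1` gives 57.4% in a functional assay on the whole organism (strain Wistar) for inhibition, with Rattus norvegicus as the target, read by paw edema, with a stated time of 30 min, at a dose of 50 mg/kg by the oral route; on this read-out lower numbers stand for less inhibition and higher numbers for more inhibition at the one dose given (going by the name of the read-out). Compound 2 `CCC(=O)N1N=C(c2ccc(C)cc2)CC1c1cn(-c2ccccc2)nc1-c1ccc(Cl)c(Cl)c1` gives 29.8%. Compound 3 `O=CN1N=C(c2ccc(F)cc2)CC1c1cn(-c2ccccc2)nc1-c1ccc(Cl)c(Cl)c1` gives 37.2%.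

Compound 3 stands second highest of these three numbers; its value and that of compound 2 lie within the scatter of each other, while compound 1 sits beyond the scatter, higher. Compound 4 `Fc1ccc(C2=NN(c3ccccc3)C(c3cn(-c4ccccc4)nc3-c3ccc(Cl)c(Cl)c3)C2)cc1` differs from compound 3 in a single place: phenyl in place of formyl on an amine nitrogen in a ring. Among the compounds with values here, one measured step bears on this change, and it runs in the opposite sense: a number 27.6 percentage points lower from compound 1 to compound 2 (beyond the scatter). There a 4-nitrophenyl group on the ring nitrogen gave way to propanoyl, and inhibition fell by a modest amount. Reversing that direction, formyl giving way to phenyl, compound 4 is expected to rise in this assay by a modest step, a number 17.8 percentage points higher from compound 3 to compound 4 (beyond the scatter). Compound 4 is therefore estimated at 55%, with a range from 40% to 70%.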

Compound 4, a percentage reported as inhibition, in the whole organism at one dose (the size of the read-out at that dose, not a potency): 44.7%
For compound 4 the middle estimate is 10.3 percentage points above the measured one, within the range that was stated.
By their numbers in this assay, from the lowest: compounds 2, 3 and 4 (each within the scatter of the next, the first and the last beyond it); then compound 1.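

With the 4-fluorophenyl group held constant in this assay, phenyl in place of formyl on the ring nitrogen gives a number 7.5 percentage points higher from compound 3 to compound 4 (within the scatter) and so leaves the read-out within the usual scatter. The earlier change at this nitrogen, a number 27.6 percentage points lower from compound 1 to compound 2 (beyond the scatter), involved a different pair of groups, and its size beyond the scatter does not carry over to this pair. Nothing shown here gives a reason for this result.

Still open, on these data alone, is whether a methoxy group or an amine on the new phenyl ring would move the number beyond the scatter.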